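Substituent variation in one growth-inhibition series

The source may hold more compounds than are shown below. What is called first, only, known or untested is meant among the compounds shown, and "the series" means these compounds.

Measured compounds:
compound 1 `O=S(=O)(NCCCNCc1ccc(Cl)cc1)c1cc(C(F)(F)F)cc(C(F)(F)F)c1`, 2900 nM
compound 2 `CC(C)(C)c1ccc(CNCCCNS(=O)(=O)c2cc(C(F)(F)F)cc(C(F)(F)F)c2)cc1`, 2500 nM
compound 3 `O=S(=O)(NCCCNCc1cccc(Cl)c1)c1cc(C(F)(F)F)cc(C(F)(F)F)c1`, 6900 nM

In a functional assay on BE(2)-C cells (Homo sapiens) for inhibition, read by MTT assay, with a stated time of 72 h (a lower number here means a stronger inhibitor of growth, a higher number a weaker inhibitor of growth), compound 2 gives the lowest of the three numbers. Compound 1 stays within the scatter of it (a 1.2-fold lower number from compound 1 to compound 2 (0.06 log units; within the scatter)), while compound 3 lies beyond it (a 2.8-fold higher number from compound 2 to compound 3 (0.44 log units; beyond the scatter)). Compound 4 `O=S(=O)(NCCCNCc1ccc(-c2ccccc2)cc1)c1cc(C(F)(F)F)cc(C(F)(F)F)c1` is not yet measured. It differs from compound 2 in one place: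

phenyl in place of tert-butyl on an aromatic carbon

Within the data shown here, only one measured step changes the group on an aromatic carbon, namely a 1.2-fold lower number from compound 1 to compound 2 (0.06 log units; within the scatter), and it stayed within the scatter. The two steps beyond the scatter, a 2.4-fold higher number from compound 1 to compound 3 (0.38 log units; beyond the scatter) and a 2.8-fold higher number from compound 2 to compound 3 (0.44 log units; beyond the scatter), exchange the whole chlorophenyl or tert-butylphenyl for 3-chlorophenyl and are a different kind of change; they give no guide to a phenyl entering. A step within the scatter is therefore expected, with no clear direction. Compound 4 is estimated at 2300 nM, with a range from 1000 nM to 5500 nM. The expected step is a 1.1-fold lower number from compound 2 to compound 4 (0.04 log units; within the scatter).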

Compound 4, concentration for 50% growth inhibition: 2600 nM
Compound 4: middle estimate off by 1.1-fold (0.05 log units), on the low side; the range from low to high includes it.
By their numbers in this assay, from the lowest: compounds 2, 4 and 1 (each within the scatter of the next); then compound 3.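

In this assay, a whole aromatic ring on this aromatic carbon, para to a large group, gives a step within the scatter, both against tert-butyl (a 1.0-fold higher number from compound 2 to compound 4 (0.02 log units; within the scatter)) and against chloro (a 1.1-fold lower number from compound 1 to compound 4 (0.05 log units; within the scatter)). The earlier compounds shown here compared only chloro and tert-butyl here; with phenyl, the series now spans groups of different size and ring content, and this assay does not separate any of the three. No evidence on why these values lie so close is at hand.

Open, on these data alone, is whether an amine or a carboxylic acid on this aromatic carbon would stay within the scatter of these three compounds. Also open, as far as these compounds go, is whether a nitrile in place of a trifluoromethyl on the shared core, or a longer chain, would leave the number where it stands.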